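This account rests on a few compounds, and the source may have more. Where it says the series, first, only, none or still open, it means among the compounds named here.

Compound 2 `COc1cc2c(Oc3ccc(NC(=O)c4cn(-c5ccccc5Cl)nn4)cc3F)ccnc2cc1OCCCN1CCC(C)CC1` is the weaker of the two compounds measured in a functional assay on NCI-H460 cells (Homo sapiens) for cytotoxicity, read by MTT assay, with a stated time of 72 h (on this read-out higher numbers stand for weaker inhibition and lower numbers for stronger inhibition), where compound 2 gives 230 nM. Among the measured compounds shown here, that is the highest of the two numbers, yet the gap to its only neighbour is small: compound 1 `COc1cc2c(Oc3ccc(NC(=O)c4cn(-c5ccccc5F)nn4)cc3F)ccnc2cc1OCCCN1CCCCC1` gives 210 nM in this assay, a difference that lies within the ordinary scatter of repeated measurements, so the two cannot be told apart. For the measured compounds named here, no step between measured compounds is available, so nothing is known yet about how a single change shifts the number.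

Compound 3 `COc1cc2c(Oc3ccc(NC(=O)c4cn(-c5ccccc5F)nn4)cc3F)ccnc2cc1OCCCN1CCC(C)CC1` is the compound still to be measured. Its difference from compound 2 is fluoro in place of chloro on an aromatic carbon. Compound 1 carries this same fluoro group on its own phenyl ring and sits at a number indistinguishable from compound 2, which gives no indication that the exchange moves the number beyond the scatter in either direction. The step from compound 2 to compound 3 is therefore expected to be a 1.0-fold lower number from compound 2 to compound 3 (0.02 log units; within the scatter), essentially none. For compound 3 in this assay the estimate is 220 nM, with a range from 110 nM to 440 nM.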

Compound 3, half-maximal inhibitory concentration: 190 nM
Compound 3: middle estimate off by 1.2-fold (0.06 log units), on the high side, within the range that was stated.
By their numbers in this assay, from the lowest: compounds 3, 1 and 2 (each within the scatter of the next).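

In this assay, among the compounds shown here, going from 2-chlorophenyl to 2-fluorophenyl, on a carbon ortho to a large group, gives a 1.2-fold lower number from compound 2 to compound 3 (0.08 log units; within the scatter) and so offers the first direct reading of a single change: at this place, one halogen can replace the other without a shift that can be told from the scatter. The second single change, methyl in place of hydrogen on a saturated ring carbon, gives a 1.1-fold lower number from compound 1 to compound 3 (0.04 log units; within the scatter) and also stays within the scatter, so neither of these two small exchanges separates the compounds on this read-out. Nothing measured here offers an explanation for why the number stays put.

As far as these compounds go, both changes are small, so it remains open whether a larger group would move the number at either place. A methoxy group or a nitrile in place of the fluoro on the aromatic ring, or a hydroxyl or an amine in place of the methyl on the saturated ring, would show whether these two places stay this insensitive.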